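Methoxy versus dimethylamino: next step in the series

The source may report more compounds than this note shows. Statements on the series, on what has been measured and on what is new or still open speak of the compounds shown alone.

Compound 1 `COc1ccc(/C=C2/S/C(=N/c3ccccc3)N(Cc3ccncc3)C2=O)cc1`: 31500 nM
Compound 2 `CN(C)c1ccc(/C=C2/S/C(=N/c3ccccc3)N(Cc3ccncc3)C2=O)cc1`: 76300 nM

Within the data shown here, in a functional assay on MCF7 cells (Homo sapiens) for cytotoxicity, read by MTT assay, with a stated time of 48 h (on this read-out lower numbers stand for stronger inhibition and higher numbers for weaker inhibition), compound 2 gives 76300 nM, the higher of the two numbers so far. Compound 3 `COc1ccc(/C=C2/S/C(=N/c3ccccc3)N(Cc3ccncc3)C2=O)cc1OC` is reached from it by 3,4-dimethoxyphenyl in place of 4-(dimethylamino)phenyl on a double-bonded chain carbon bound to a double-bonded ring carbon.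

Among the measured compounds shown here, one measured step bears on this: a 2.4-fold higher number from compound 1 to compound 2 (0.38 log units; beyond the scatter), a modest change beyond the scatter. Compound 3 bears methoxy rather than dimethylamino, as compound 1 does at 31500 nM, so a return towards that number is expected. For the measured compounds named here, no measured step covers the added methoxy, which widens the range. The expected step is a 2.2-fold lower number from compound 2 to compound 3 (0.34 log units; beyond the scatter), a modest one towards a lower number. For compound 3 the estimated value in this assay is 35000 nM, with an expected range of 15000 nM to 85000 nM.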

Compound 3, half-maximal inhibitory concentration: 80700 nM
The estimate for compound 3 lay 2.3-fold (0.36 log units) below the measured number, within the range that was stated.
By their numbers in this assay, from the lowest: compound 1; then compounds 2 and 3 (each within the scatter of the next).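

In this assay methoxy in place of hydrogen on an aromatic carbon gives a 2.6-fold higher number from compound 1 to compound 3 (0.41 log units; beyond the scatter) and so moves the number away from that of compound 1, which the earlier pair could not show. The exchange of 4-(dimethylamino)phenyl for 3,4-dimethoxyphenyl on a double-bonded chain carbon bound to a double-bonded ring carbon gives a 1.1-fold higher number from compound 2 to compound 3 (0.02 log units; within the scatter) and so leaves these two different aryl groups reading alike, with only compound 1 standing apart among the three compounds. Nothing on hand accounts for this result.

Still open, from the compounds shown here alone, is whether the number of compound 1 is particular to methoxy, or whether a chlorine or a hydroxy group on the same aromatic carbon would read alike. Also open, going by these compounds, is whether a longer alkoxy chain such as ethoxy in place of methoxy would follow the same course.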